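Aryl substituent swaps on a shared triazole-free series: compound 4

This account rests on a few compounds, and the source may have more. Where it says the series, first, only, none or still open, it means among the compounds named here.

Compounds measured in a functional assay on HCT-116 cells (Homo sapiens) for inhibition, read by MTT assay, with a stated time of 48 h; on this read-out higher numbers stand for weaker inhibition and lower numbers for stronger inhibition:
compound 1 `Fc1ccccc1CSc1nnc(-c2ccncc2)n1-c1ccccc1`, 12000 nM
compound 2 `Brc1ccc(CSc2nnc(-c3ccncc3)n2-c2ccccc2)cc1`, 11100 nM
compound 3 `COc1ccc(/C=N/NC(=O)CSc2nnc(-c3ccncc3)n2-c2ccccc2)cc1`, 19200 nM

Compound 3, `COc1ccc(/C=N/NC(=O)CSc2nnc(-c3ccncc3)n2-c2ccccc2)cc1`, gives 19200 nM in this assay. Its gaps to compound 1 and to compound 2 both lie within the scatter, so the three numbers stand together and none of them is set apart.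

Compound 4 is `O=C(CSc1nnc(-c2ccncc2)n1-c1ccccc1)N/N=C/c1ccc(F)cc1`. It differs from compound 3 by fluoro in place of methoxy on an aromatic carbon; seen one bond further out, 4-methoxyphenyl becomes 4-fluorophenyl.

Among the measured compounds shown here, the one measured step, a 1.1-fold lower number from compound 1 to compound 2 (0.03 log units; within the scatter), is a change of aryl group on a saturated chain carbon bound to a sulfur, not on the same ring as the present change, and it stayed within the scatter. For the measured compounds named here, no measured step touches the methoxy of compound 3. On this thin basis compound 4 is expected to sit close to compound 3, with an estimated step of a 1.1-fold lower number from compound 3 to compound 4 (0.05 log units; within the scatter) and no change beyond the scatter.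

The estimate for compound 4 in this assay is 17000 nM, with a range from 8000 nM to 36000 nM.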

Compound 4, half-maximal inhibitory concentration: 7040 nM
The estimate for compound 4 lay 2.4-fold (0.38 log units) above the measured number; measured number outside the range, below it.
By their numbers in this assay, from the lowest: compounds 4, 2, 1 and 3 (each within the scatter of the next, the first and the last beyond it).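

In this assay, among the compounds shown here, fluoro in place of methoxy on an aromatic carbon gives the only step in this short series that lies beyond the scatter, a 2.7-fold lower number from compound 3 to compound 4 (0.44 log units; beyond the scatter), although it is modest. For the compounds shown here, the earlier step, a 1.1-fold lower number from compound 1 to compound 2 (0.03 log units; within the scatter), stayed within the scatter and involved an aryl group on a saturated chain carbon bound to a sulfur, so this is the first sign that a single substituent change can register in this read-out, here on the ring that carries the methoxy in compound 3. No measured evidence explains the step.

On these data alone, it remains open whether the step follows the departure of methoxy or the arrival of fluoro. A hydrogen, a chloro or an amine in the same place would help separate the two, and would show whether the trend extends beyond this one pair.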